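Phenoxy to benzyloxy on the shared core

The compounds below may be only part of what the source reports. "The series", "measured", "known", "first", "only" and "open" are said of these compounds alone.

Measured so far in a functional assay for inhibition, with Homo sapiens as the target; a higher number here means a weaker inhibitor, a lower number a stronger inhibitor:
- compound 1 `COc1ccc2sc(C(=O)Nc3nn[nH]n3)c(OC(C)(C)C)c2c1`: > 100000 nM (a limit of the assay, not a number)
- compound 2 `COc1ccc2sc(C(=O)Nc3nn[nH]n3)c(Oc3ccccc3)c2c1`: 10100 nM

Among the compounds with values here, compound 2 carries the only actual number so far, so there is no spread of values against which to rank it. The reading for compound 1 is a limit.

Compound 3 `COc1ccc2sc(C(=O)Nc3nn[nH]n3)c(OCc3ccccc3)c2c1` keeps the shared core and differs from compound 2 at one place, with benzyl in place of phenyl on an oxygen on an aromatic ring. In other words, phenoxy becomes benzyloxy.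

Within the data shown here, one measured step bears on this change: an at least 9.9-fold lower number from compound 1 to compound 2 (0.99 log units; beyond the scatter). It shows that the group on this oxygen can matter in this assay, but its size is bounded only by a limit, and it exchanged tert-butyl for phenyl. Here, a six-membered aromatic ring of carbon only is present on both sides of the change, so a smaller step is expected, with no firm direction. The expected step is a 1.0-fold lower number from compound 2 to compound 3 (0.00 log units; within the scatter). For compound 3 the estimate is 10000 nM, with an expected range of 3000 nM to 40000 nM.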

Compound 3, half-maximal inhibitory concentration: 23400 nM
Beside the measured number, compound 3's estimate is 2.3-fold (0.37 log units) below it; measured number inside the range.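

In this assay, a six-membered aromatic ring of carbon only stands on both sides of the change, yet the number still moves, with a 2.3-fold higher number from compound 2 to compound 3 (0.36 log units; beyond the scatter). The ring alone therefore does not set the reading at this position: phenyl and benzyl on this oxygen are not interchangeable, although the gap is modest, and compound 2 gives the lowest number of the three. Benzyl in place of tert-butyl gives an at least 4.2-fold lower number from compound 1 to compound 3 (0.63 log units; beyond the scatter), which is a bound and not a measured size, since the reading for compound 1 is a limit of the assay: the limit of > 100000 nM in this assay, at which 1 of the 3 values shown sits.

As far as these compounds go, the effect of a longer chain on this oxygen, such as phenylethyl, remains open, and two actual numbers cannot show whether the number keeps rising as the link to the ring grows. Also open, from the compounds shown here alone, is how a ring carrying an amine or a carboxylic acid would read in this assay, so the phenoxy group of compound 2 is only the best of a very small set at this position.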